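Phenyl on the Amide-Type Nitrogen of Compound 2

The source may report more compounds than this note shows. Statements on the series, on what has been measured and on what is new or still open speak of the compounds shown alone.

Compound 2 (`Cn1cc(C2=C(c3nn(CCCn4cccc4)c4ncccc34)C(=O)NC2=O)c2ccccc21`) gives 21600 nM in a functional assay on K562 cells (Homo sapiens) for antiproliferative activity, read by MTT assay, with a stated time of 48 h (a lower number here means a stronger inhibitor, a higher number a weaker inhibitor), and stands within the scatter of the two other measured compounds. The nearest neighbour is compound 1 (`Cn1cc(C2=C(c3nn(CCn4ccnc4)c4ncccc34)C(=O)N(c3ccccc3)C2=O)c2ccccc21`) at 26400 nM in this assay and the furthest is compound 3 (`Cn1cc(C2=C(c3nn(CCCCn4ccnc4)c4ncccc34)C(=O)NC2=O)c2ccccc21`) at 31800 nM in the same read-out, yet neither gap exceeds the scatter.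

The step to compound 4 (`Cn1cc(C2=C(c3nn(CCCn4cccc4)c4ncccc34)C(=O)N(c3ccccc3)C2=O)c2ccccc21`) places phenyl in place of hydrogen on an amide-type nitrogen in a ring. Among the measured compounds shown here, the one measured step, a 1.5-fold higher number from compound 2 to compound 3 (0.17 log units; within the scatter), concerns the chain and not this nitrogen, so it says little about the new group, and it stays within the scatter. For the measured compounds named here, no measured pair isolates the phenyl group. The closest evidence is compound 1, which carries phenyl on that same nitrogen but also has a different chain, and compound 1 at 26400 nM remains within the scatter of compound 2. On this thin basis, no change beyond the scatter is expected in this assay, and the range is kept wide. The expected step is a 1.1-fold higher number from compound 2 to compound 4 (0.05 log units; within the scatter) and would lie within the scatter. The estimate for compound 4 is 24000 nM (expected range 11000 nM to 50000 nM).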

Compound 4, half-maximal inhibitory concentration: 36600 nM
For compound 4 the middle estimate is 1.5-fold (0.18 log units) below the measured one; the measured number falls inside the stated range.
By their numbers in this assay, from the lowest: compounds 2, 1, 3 and 4 (each within the scatter of the next).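

With the direct pair now in hand, phenyl in place of hydrogen on an amide-type nitrogen in a ring gives, in this assay, a 1.7-fold higher number from compound 2 to compound 4 (0.23 log units; within the scatter), so this position accepts a group of six carbon atoms in place of the amide hydrogen without a step beyond the scatter. With phenyl held on that nitrogen, (1H-pyrrol-1-yl)methyl in place of 1H-imidazol-1-yl on a saturated chain carbon gives a 1.4-fold higher number from compound 1 to compound 4 (0.14 log units; within the scatter), which shows that this chain change also stays within the scatter when phenyl is present. No available measurement bears on the reason for either step.

From the compounds shown here alone, whether methyl or benzyl on that same nitrogen, or a phenyl ring carrying an amine or a carboxylic acid, would give a step beyond the scatter remains open. Going by these compounds, it also remains open whether a chain longer than that of compound 3, or one ending in a morpholine ring, would separate any compound from the others in this assay.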